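The compounds below may be only part of what the source reports. "The series", "measured", "known", "first", "only" and "open" are said of these compounds alone.

Measured compounds:
Compound 1, `O=C(CCc1cn(Cc2ccc3oc(-c4ccccc4)cc(=O)c3c2)nn1)Nc1ccc(F)cc1`: 15600 nM
Compound 2, `O=C(CCc1cn(Cc2ccc3oc(-c4ccccc4)cc(=O)c3c2)nn1)Nc1ccc(Cl)cc1`: 15600 nM
Compound 3, `O=C(CCCCc1cn(Cc2ccc3oc(-c4ccc(Cl)cc4)cc(=O)c3c2)nn1)Nc1ccccc1`: 32900 nM

In an assay on isolated protein for inhibition of Amine oxidase [flavin-containing] B (Homo sapiens), read by fluorescence and spectrophotometry (a higher number here means a weaker inhibitor, a lower number a stronger inhibitor), compound 3 stands at the highest of the three numbers, beyond the scatter from both compound 1 and compound 2, which sit together. Compound 4, `O=C(CCCCc1cn(Cc2ccc3oc(-c4ccccc4)cc(=O)c3c2)nn1)Nc1ccccc1`, differs from compound 3 by hydrogen in place of chloro on an aromatic carbon. Within the data shown here, only one measured step bears on this change, and only loosely: no change at the digits printed from compound 1 to compound 2 (within the scatter), a halogen swap on a different ring. Among the measured compounds shown here, no measured pair removes a halogen altogether, so the direction for compound 4 is open. The expected step is a 1.3-fold lower number from compound 3 to compound 4 (0.12 log units; within the scatter), nothing beyond the scatter. The estimate for compound 4 in this assay is 25000 nM, within a range from 10000 nM to 60000 nM.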

Compound 4, half-maximal inhibitory concentration: 15600 nM
Compound 4: middle estimate off by 1.6-fold (0.20 log units), on the high side; the measured number falls inside the stated range.
By their numbers in this assay, from the lowest: compounds 1, 2 and 4 (each within the scatter of the next); then compound 3.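

Taking the chloro off the 4-chlorophenyl group gives a 2.1-fold lower number from compound 3 to compound 4 (0.32 log units; beyond the scatter), the first measured step that removes a halogen rather than swapping one, and it is modest. The phenyl compound then stands level with the other two, with no change at the digits printed from compound 2 to compound 4 (within the scatter) and no change at the digits printed from compound 1 to compound 4 (within the scatter), although these two steps also change the chain. Nothing on record accounts for the chloro step. As far as these compounds go, whether a methyl, a methoxy or an amine in the same place would read like the chloro or like the hydrogen stays open. So does whether the chloro would give a similar step on the shorter chain of compound 1.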